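Swapping the aryl group on a tetrabromobenzotriazole alcohol

This account rests on a few compounds, and the source may have more. Where it says the series, first, only, none or still open, it means among the compounds named here.

Measured so far:
- compound 1, `COc1cccc(C(O)CCn2nc3c(Br)c(Br)c(Br)c(Br)c3n2)c1`: 58%
- compound 2, `C[C@@H](O)CCn1nc2c(Br)c(Br)c(Br)c(Br)c2n1`: 69%

Both compounds were tested in a functional assay on CCRF-CEM cells (Homo sapiens) for antiproliferative activity, read by MTT assay, with a stated time of 24 h, tested at 50 uM; a lower number here means a stronger effect, a higher number a weaker effect of the compound at the concentration tested. In this assay compound 1 gives 58%, and compound 2 gives 69%. Of these two numbers, compound 1 stands at the lower end, the gap to compound 2 lying beyond the usual scatter, so compound 1 shows the stronger effect of the pair.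

Compound 3, `OC(CCn1nc2c(Br)c(Br)c(Br)c(Br)c2n1)c1ccc(Br)cc1`, has not yet been measured. It differs from compound 1 in one place: 4-bromophenyl in place of 3-methoxyphenyl on a saturated chain carbon bound to an oxygen on a saturated carbon and a saturated chain carbon

Among the measured compounds shown here, nothing measured so far separates the contribution of one aryl group from another, so the step from compound 1 to compound 3 has no direct precedent here. The expectation is a small step, if any, with the estimated change being a number 3 percentage points lower from compound 1 to compound 3 (within the scatter), a shift that may well sit within the scatter. Compound 3 is therefore estimated at 55%, with a plausible range from 40% to 72%.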

Compound 3, a percentage reported as activity, at one concentration (the size of the read-out at that concentration, not a potency): 58%
Beside the measured number, compound 3's estimate is 3 percentage points below it, and the stated range covers the measured number.
By their numbers in this assay, from the lowest: compounds 1 and 3 (each within the scatter of the next); then compound 2.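

In this assay, putting 4-bromophenyl in place of 3-methoxyphenyl on this saturated chain carbon gives no change at the digits printed from compound 1 to compound 3 (within the scatter). This position therefore takes two differently substituted phenyl groups with no visible difference in effect, and the hydrogen-bond acceptor counted in 3-methoxyphenyl, absent from 4-bromophenyl, can go without any loss showing in this pair. No independent measurement bears on why these two groups read alike.

This swap alters both the substituent and its place on the phenyl ring, so the pair cannot show what either alteration would do alone, and the two could even offset each other. As far as these compounds go, it also remains open whether a phenyl ring carrying an amine or a carboxylic acid, or a cyclohexyl ring at this carbon, would read differently.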